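Swapping thiophen-2-yl for phenoxymethyl on a carbonyl carbon

This account rests on a few compounds, and the source may have more. Where it says the series, first, only, none or still open, it means among the compounds named here.

Measured in an ADME assay on HepG2 2.2.15 cells (Homo sapiens) for cytotoxicity; on this read-out lower numbers stand for higher toxicity in this test and higher numbers for lower toxicity in this test:
- compound 1 `COCC(=O)OCCc1c(-c2ccccc2Cl)c2cc(Cl)ccc2[nH]c1=O`: 74000 nM
- compound 2 `O=C(OCCc1c(-c2ccccc2Cl)c2cc(Cl)ccc2[nH]c1=O)c1cccs1`: > 1700000 nM (a limit)

Compound 2 stands at > 1700000 nM, which is a limit of this assay and not a number. Compound 3 `O=C(COc1ccccc1)OCCc1c(-c2ccccc2Cl)c2cc(Cl)ccc2[nH]c1=O` carries phenoxymethyl in place of thiophen-2-yl on a carbonyl carbon. Going by the values given here, the only measured step at this place is large: an at least 22-fold higher number from compound 1 to compound 2 (1.36 log units; beyond the scatter). Phenoxymethyl holds an aromatic ring, as thiophen-2-yl does, yet it also resembles the methoxymethyl of compound 1, at 74000 nM. A clear move towards lower numbers is therefore expected, and the expected step is an at least 5.6-fold lower number from compound 2 to compound 3 (0.75 log units; beyond the scatter). Compound 3 is estimated at 300000 nM, with an expected range of 60000 nM to 1500000 nM.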

Compound 3, half-maximal cytotoxic concentration: 81000 nM
Compound 3: middle estimate off by 3.7-fold (0.57 log units), on the high side; the measured number falls inside the stated range.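

An aromatic ring on its own does not account for the high limit, since phenoxymethyl also holds one and still gives an at least 20-fold lower number from compound 2 to compound 3 (1.32 log units; beyond the scatter) in this assay. Phenyl in place of methyl on an oxygen on a saturated carbon gives a 1.1-fold higher number from compound 1 to compound 3 (0.04 log units; within the scatter), so at this place the two groups with that oxygen stand level. Compound 2 has only a limit and not an exact number: the limit of > 1700000 nM in this assay, at which 1 of the 3 values shown sits.

Open, from the compounds shown here alone, is whether phenyl on the carbonyl carbon would behave like thiophen-2-yl or like phenoxymethyl. Going by these compounds, an amine on this carbonyl carbon also remains open.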